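This account rests on a few compounds, and the source may have more. Where it says the series, first, only, none or still open, it means among the compounds named here.

In an ADME assay on MRC5 cells (Homo sapiens) for inhibition, with a stated time of 72 h (a lower number here means that less compound is needed, a higher number that more compound is needed for the effect), compound 1 (`COc1cccc(OC)c1C(=O)Nc1c[nH]nc1C(=O)NC1CCC1`) gives > 50000 nM, which is a limit of the assay and not a number. Compound 2 (`COc1cccc(OC)c1C(=O)Nc1c[nH]nc1C(=O)NCC1CCCCC1`) gives > 50000 nM, again only a limit. Going by the values given here, the evidence so far amounts to the limit of > 50000 nM in this assay, at which 2 of the 2 values shown sit, and the one measured change, a step that the two limits leave unreadable from compound 1 to compound 2, offers no size to carry over. Compound 3 (`COc1cccc(OC)c1C(=O)Nc1c[nH]nc1C(=O)NCCN1CCCC1`) alters the side chain of compound 2: (pyrrolidin-1-yl)methyl in place of cyclohexyl on a saturated chain carbon bound to an amide-type nitrogen. In this assay no shift beyond the usual scatter is expected, and the estimated move is a number no higher from compound 2 to compound 3 (the limit leaves the size open). For compound 3 the estimate is 50000 nM, with an expected range of 20000 nM to 100000 nM.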

Compound 3, half-maximal effective concentration: > 50000 nM
Compound 3: no number, only a limit; the forecaster's own chance of this, stated with the estimate: 80%; the middle value lies on the limit itself.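

In this assay, going by these compounds alone, compound 3 stays at a limit, as compound 1 and compound 2 do, so no step among the three can be read. The compounds shown leave open whether any amide side chain on the shared core gives a measurable half-maximal effective concentration.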